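The source may hold more compounds than are shown below. What is called first, only, known or untested is meant among the compounds shown, and "the series" means these compounds.

Measured compounds and their values in the cytotoxicity assay:

compound 1, `O=S(=O)(Nc1ccc(-c2nc3ccccc3o2)cc1)c1ccccc1O`: > 100000 nM
compound 2, `O=S(=O)(Nc1ccc2oc(-c3ccccc3)nc2c1)c1ccccc1Cl`: 73000 nM
compound 3, `O=S(=O)(Nc1ccc(-c2nc3ccccc3o2)cc1)c1ccc(Cl)c(C(F)(F)F)c1`: 69000 nM

Of the compounds shown here, three have been tested in an ADME assay on HEK293 cells (Homo sapiens) for cytotoxicity, read by resazurin assay, with a stated time of 48 h; a higher number here means that more compound is tolerated, a lower number that less compound is tolerated. Among the compounds with values here, compound 1 gives only a limit there, > 100000 nM, and not a number; it is the one compound of the three that sits at the limit of > 100000 nM in this assay, at which 1 of the 3 values shown sits. Compound 2 gives a number, 73000 nM, and compound 3 gives 69000 nM; these two values lie within the usual scatter of each other, so no order between them can be read. Since compound 1 is known only as a limit, the size of any gap between it and compound 2 or compound 3 is not known either.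

Compound 4, `O=S(=O)(Nc1ccc(-c2nc3ccccc3o2)cc1)c1ccc(F)cc1`, has not yet been measured. It differs from compound 1 in one place: 4-fluorophenyl in place of 2-hydroxyphenyl on a sulfonyl sulfur. Within the data shown here, no step between two measured compounds shows what such an exchange on the sulfonyl sulfur does in this assay, so the expectation rests on the spread of the three values seen. All of them lie in a narrow band at the upper end of the concentration range, and a step from compound 1 to compound 4 of no more than the usual scatter is expected, an at least 1.1-fold lower number from compound 1 to compound 4 (0.07 log units; that floor lies within the scatter), with a slight lean toward the region where compound 2 and compound 3 sit. Compound 4 is therefore estimated at 85000 nM, between 40000 nM and 180000 nM, with a fair chance that the assay again reports only a limit.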

Compound 4, half-maximal cytotoxic concentration: > 100000 nM
Compound 4: a limit, no number (the forecaster's own chance of this, stated with the estimate: 40%); middle value at least 1.1-fold (0.07 log units) away from the limit.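

Compound 1 and compound 4 each give only a limit in this assay, and not a number, so no step between them can be read: the limit of > 100000 nM in this assay, at which 2 of the 4 values shown sit.

The compounds shown leave open whether 4-fluorophenyl in place of 2-hydroxyphenyl on a sulfonyl sulfur changes the tolerated concentration in this assay at all, and if so, in which direction and by how much.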